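Pyridinyl pyrimidine antagonists: an amino group replaces methoxy

This account rests on a few compounds, and the source may have more. Where it says the series, first, only, none or still open, it means among the compounds named here.

Compounds measured in a functional assay on cells for antagonist activity at Free fatty acid receptor 1 (Homo sapiens), read by TR-FRET and inositol phosphate accumulation, with a stated time of 2 h; on this read-out higher numbers stand for weaker inhibition and lower numbers for stronger inhibition:
compound 1 `Cc1cc(COc2ccccc2F)nc(-c2ccccn2)n1` gives 398 nM
compound 2 `Cc1cc(COc2c(F)ccc(F)c2F)nc(-c2ccccn2)n1` gives 1580 nM
compound 3 `COc1cc(COc2cccc(F)c2)nc(-c2ccccn2)n1` gives 1260 nM

Among these three numbers compound 3 stands second highest. Its nearest neighbour is compound 2, whose value lies within the usual scatter of compound 3, so nothing can be said about an order between these two. Compound 1, at the far end, gives a number well below that of compound 3, a gap beyond the scatter, so compound 1 is the stronger inhibitor of the pair.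

Compound 4 `CC(C)Nc1cc(COc2cccc(F)c2)nc(-c2ccccn2)n1` is not yet measured. It differs from compound 3 in one place: isopropylamino in place of methoxy on an aromatic carbon. For the measured compounds named here, no measured pair shows this kind of change, so its effect on this assay is unknown from these data. Given that, compound 4 is expected to stay close to compound 3, with a step of a 1.3-fold lower number from compound 3 to compound 4 (0.10 log units; within the scatter) that should fall within or only slightly beyond the scatter. Compound 4 is therefore estimated at 1000 nM, with a plausible range from 300 nM to 3500 nM.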

Compound 4, half-maximal inhibitory concentration in the Free fatty acid receptor 1 assay: 100 nM
Compound 4: the middle estimate sits 10-fold (1.00 log units) above what was measured; the whole stated range lies above it.
By their numbers in the Free fatty acid receptor 1 assay, from the lowest: compound 4; then compound 1; then compounds 3 and 2 (each within the scatter of the next).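

For the compounds shown here, in the Free fatty acid receptor 1 assay this position, opposite the ring nitrogen, proves highly sensitive to the group it carries, which the earlier compounds could not show: isopropylamino in place of methoxy gives a 13-fold lower number from compound 3 to compound 4 (1.10 log units; beyond the scatter). The entering group brings a hydrogen-bond donor and more heavy atoms, and it joins the aromatic carbon through nitrogen instead of oxygen. In a physicochemical assay for lipophilicity, at pH 7.4 (on this read-out lower numbers stand for lower lipophilicity and higher numbers for higher lipophilicity), compound 3 gives 3.6 and compound 4 gives 4.3. The same change also raises lipophilicity, which may account for part of the gain in inhibition: the measured distribution coefficient of compound 3, 3.6, and of compound 4, 4.3, a number 0.70 log units higher (beyond the scatter).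

The compounds shown leave open whether the gain follows the amino nitrogen with its hydrogen or the branched carbon chain, a question that a methylamino group or a plain isopropyl group at this position would help to settle. Going by these compounds, it also remains open whether isopropylamino in place of the methyl group of compound 1 would act in the same way.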